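The source may hold more compounds than are shown below. What is called first, only, known or untested is meant among the compounds shown, and "the series" means these compounds.

Measured in an ADME assay for lipophilicity (on this read-out lower numbers stand for lower lipophilicity and higher numbers for higher lipophilicity), so far:
compound 1 `O=c1ccocc1O` gives -0.92
compound 2 `COCc1cc(=O)c(O)co1` gives -0.62
compound 3 `CCn1cccc(O)c1=O` gives 0.2

Compound 3 stands highest of the three, beyond the scatter from both others. Compound 4 `CCCCn1cccc(O)c1=O` differs from it by ethyl in place of hydrogen on a saturated chain carbon, two bonds along the chain from an aromatic nitrogen. Among the compounds with values here, only one measured step bears on this, and loosely: a number 0.30 log units higher from compound 1 to compound 2 (within the scatter), with methoxymethyl in place of hydrogen on an aromatic carbon. That is a different group in a different place. The series holds no measured lengthening of a chain, so the size rests on the structural change alone. A rise beyond the scatter in this assay is expected, estimated as a number 1.00 log units higher from compound 3 to compound 4 (beyond the scatter), though with little support from the data. For compound 4 the estimated value is 1.2, with an expected range from 0.8 to 1.6.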

Compound 4, distribution coefficient: 1.18
The estimate for compound 4 lay 0.02 log units above the measured number; low and high end bracket the measured number.
By their numbers in this assay, from the lowest: compounds 1 and 2 (each within the scatter of the next); then compound 3; then compound 4.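

Ethyl in place of hydrogen on a saturated chain carbon, two bonds along the chain from an aromatic nitrogen, gives a number 0.98 log units higher from compound 3 to compound 4 (beyond the scatter) in this assay and is the only chain lengthening measured in the series. The entering ethyl carries no hydrogen-bond donors or acceptors and no net charge, so the number moves beyond the scatter with those counts unchanged. Nothing on hand accounts for the size of this step.

As far as these compounds go, whether a chain longer than butyl continues the rise remains open, as does where an amine or a carboxylic acid on the chain would place the number.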